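One Ring Stereocentre Changed in Compound 3

A few compounds are considered here, and "the series" means these few. Any claim that something is new, unique, unknown or untested is made for them only; others in the source may bear on it.

Compound 1 `Nc1ncnc2c1ncn2/C=C1/C[C@H]1[C@H](O)CO` and compound 2 `Nc1ncnc2c1ncn2/C=C1\C[C@H]1[C@H](O)CO` have both been measured in an ADME assay on HFF cells (Homo sapiens) for cytotoxicity, read by neutral red uptake (on this read-out lower numbers stand for higher toxicity in this test and higher numbers for lower toxicity in this test), so far. There compound 1 gives 206000 nM and compound 2 gives 194000 nM as its half-maximal cytotoxic concentration. Within the data shown here, compound 2 thus stands within the scatter of the only other number available. Compound 3 `Nc1ncnc2c1ncn2/C=C1\C[C@@H]1[C@H](O)CO` departs from compound 2 in one place: the two compounds have the same atoms and bonds and differ only in configuration as drawn: 1 of 3 stereo elements differ; a stereocentre at a saturated ring carbon is drawn R in compound 2 and S in compound 3 and nothing else. Among the measured compounds shown here, the single measured step, a 1.1-fold lower number from compound 1 to compound 2 (0.03 log units; within the scatter) in size, bears on this only indirectly. Since the fact that compounds 1 and 2 differ only in the configuration as drawn holds for that step too, it is also a change of configuration alone, but it concerns the double bond and not this stereocentre. For the measured compounds named here, no measured step touches the ring carbon itself, so the inference is weak. In this assay no change beyond the scatter is expected, and the estimated step is a 1.0-fold higher number from compound 2 to compound 3 (0.00 log units; within the scatter) in size. For compound 3 the estimated value is 195000 nM with an expected range from 90000 nM to 350000 nM in this test.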

Compound 3, half-maximal cytotoxic concentration: > 300000 nM
Compound 3 ended at the assay's limit; the forecaster's own chance of this, stated with the estimate: 15%; middle value at least 1.5-fold (0.18 log units) from the limit.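

Among these compounds, this is the first reading of the saturated ring stereocentre itself: in this assay, drawing it S in place of R gives an at least 1.5-fold higher number from compound 2 to compound 3 (0.18 log units; that floor lies within the scatter), so even the floor of this step does not go beyond the scatter. For compound 3 the value > 300000 nM is a limit of this assay and not a number. With the double bond changed as well, the reading is an at least 1.4-fold higher number from compound 1 to compound 3 (0.16 log units; that floor lies within the scatter), which does not separate the two changes of configuration and likewise remains only a floor.

The compounds shown leave open how far compound 3 lies past that limit, and so whether the ring stereocentre has any effect beyond the scatter. They also leave open whether this configuration would read the same with an amine in place of a hydroxyl group.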